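Swapping the Aryl Group on a Melanin-Concentrating Hormone Ligand

This account rests on a few compounds, and the source may have more. Where it says the series, first, only, none or still open, it means among the compounds named here.

Of the compounds shown here, three built on one shared core have been measured in an assay on isolated protein for binding affinity to melanin-concentrating hormone receptor 1 (Homo sapiens); on this read-out higher numbers stand for weaker inhibition and lower numbers for stronger inhibition. Compound 1 `CN(C(=O)N1CC[C@H](n2cnc3cc(-c4ccc(Cl)cc4)sc3c2=O)C1)[C@H]1CCN(C2CCC(C)(C)CC2)C1` gives 2 nM in this assay. Compound 2 `COc1ccc(-c2cc3ncn([C@H]4CCN(C(=O)N(C)[C@H]5CCN(C)C5)C4)c(=O)c3s2)cc1` gives 21 nM in this assay. Compound 3 `CN(C(=O)N1CC[C@H](n2cnc3cc(-c4ccc(C(F)(F)F)cc4)sc3c2=O)C1)[C@H]1CCN(C2CCOCC2)C1` gives 19 nM in this assay. Of these three numbers, compound 3 stands second highest. Its nearest neighbour is compound 2, and the two lie within the usual scatter of repeated measurements, so no order can be read between them. The furthest is compound 1, whose clearly lower number lies beyond the scatter.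

The next compound, compound 4 `CCOc1ccc(-c2cc3ncn([C@H]4CCN(C(=O)N(C)[C@H]5CCN(C6CCOCC6)C5)C4)c(=O)c3s2)c(Cl)c1`, has not yet been measured. It differs from compound 3 in a single place: 2-chloro-4-ethoxyphenyl in place of 4-(trifluoromethyl)phenyl on an aromatic carbon. Among the measured compounds no pair differs only in this way, so no step of the same kind is available to lean on. Compound 2 and compound 3 differ in more than one place, so what their two values show cannot be traced to the aromatic group alone. The expected step is therefore a modest one, a 1.9-fold lower number from compound 3 to compound 4 (0.28 log units; within the scatter), toward a somewhat lower number, though it may turn out no larger than the scatter. In this assay compound 4 is expected to give about 10 nM, within a range from 3 nM to 40 nM.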

Compound 4, inhibition constant: 14 nM
Estimate against measurement, compound 4: 1.4-fold (0.15 log units) below; measured number inside the range.
By their numbers in this assay, from the lowest: compound 1; then compounds 4, 3 and 2 (each within the scatter of the next).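

Among the compounds shown here, this is the first direct reading at this position, the aromatic carbon next to the ring sulfur: with the rest of the molecule unchanged, 2-chloro-4-ethoxyphenyl in place of 4-(trifluoromethyl)phenyl gives a 1.4-fold lower number from compound 3 to compound 4 (0.13 log units; within the scatter) in this assay for this pair. The two groups carry different atoms, since one has three fluorines while the other has a chlorine and an oxygen that counts as a hydrogen-bond acceptor, yet this measurement does not tell them apart, so at this position, for these two groups, the exchange leaves no readable mark on the value. No measured property of these compounds bears on this result.

Because chloro and ethoxy entered together, this pair cannot say what either contributes alone, and a phenyl ring carrying only one of them, on the otherwise unchanged molecule, would separate the two. Also open, going by these compounds, is whether this position stays as undemanding with a group of a different kind, such as a phenyl ring bearing a carboxylic acid or an amine, or a pyridine ring in place of the phenyl ring.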